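The compounds below may be only part of what the source reports. "The series", "measured", "known", "first", "only" and "open" are said of these compounds alone.

Measured so far in a functional assay on K562 cells (Homo sapiens) for cytotoxicity, read by CCK-8 assay, with a stated time of 72 h; a lower number here means a stronger inhibitor, a higher number a weaker inhibitor: compound 1 `C=CCn1c(=O)/c(=C\c2cc(Br)ccc2F)[nH]c(=O)/c1=C\c1ccccc1OC` gives 5100 nM; compound 2 `C=CCn1c(=O)/c(=C\c2ccccc2OC)[nH]c(=O)/c1=C\c1ccccc1OC` gives 7400 nM; compound 3 `COc1ccccc1/C=c1/[nH]c(=O)/c(=C\c2ccccc2OC)[nH]c1=O`, which lacks the allyl chain of the shared core, is reported as "not active" (no number reported) with no number given.

Compound 2 has the highest of the two numbers, though its step to compound 1 is small: a 1.5-fold higher number from compound 1 to compound 2 (0.16 log units; within the scatter). Compound 4 `C=CCn1c(=O)/c(=C\c2ccccc2F)[nH]c(=O)/c1=C\c1ccccc1OC` differs from compound 2 only by fluoro in place of methoxy on an aromatic carbon. Within the data shown here, the one step that bears on this change, the swap between a 5-bromo-2-fluorophenyl and a 2-methoxyphenyl on the same chain carbon, stayed within the scatter, so no movement beyond the scatter is expected here either: the estimated step is a 1.2-fold lower number from compound 2 to compound 4 (0.09 log units; within the scatter). Compound 4 is therefore expected to give about 6000 nM, with a likely range from 3000 nM to 14000 nM.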

Compound 4, half-maximal inhibitory concentration: 5600 nM
For compound 4 the middle estimate is 1.1-fold (0.03 log units) above the measured one, and the stated range covers the measured number.
By their numbers in this assay, from the lowest: compounds 1, 4 and 2 (each within the scatter of the next).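

Fluoro in place of methoxy on this aromatic carbon gives a 1.3-fold lower number from compound 2 to compound 4 (0.12 log units; within the scatter) in this assay, so a second substituent swap at this ortho place also stays within the scatter. Hydrogen in place of bromo gives a 1.1-fold higher number from compound 1 to compound 4 (0.04 log units; within the scatter), which shows that the bromo on this ring is not needed to keep the number in this range. No measurement here explains these small steps. From the compounds shown here alone, whether an amine or a carboxylic acid on this aromatic carbon would move the number beyond the scatter remains open.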